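Shortening the amino acid arm on two quinone cores

The source may report more compounds than this note shows. Statements on the series, on what has been measured and on what is new or still open speak of the compounds shown alone.

Compound 1 `CC1=CCC[C@H]2[C@](C)(CC3=CC(=O)C=C(N[C@@H](CC(C)C)C(=O)O)C3=O)[C@@H](C)CC[C@]12C` joins a large bicyclic core to a quinone ring that carries an amino acid arm. In an ADME assay on MRC5 cells (Homo sapiens) for cytotoxicity, read by MTT assay, with a stated time of 72 h (a lower number here means a stronger inhibitor, a higher number a weaker inhibitor), compound 1 gives 73400 nM. Compound 3 `CC1=CCC[C@H]2[C@](C)(CC3=CC(=O)C=C(N[C@@H](C)C(=O)O)C3=O)[C@@H](C)CC[C@]12C` keeps the same core and differs only in the arm: hydrogen in place of isopropyl on a saturated chain carbon, two bonds along the chain from an amine nitrogen and a carbonyl carbon. In this assay compound 3 gives 157000 nM, and the change is recorded as a 2.1-fold higher number from compound 1 to compound 3 (0.33 log units; beyond the scatter), so the shorter arm made the compound a somewhat weaker inhibitor of the cells.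

Compound 2 `CC(C)C[C@H](NC1=CC(=O)C=C(C(C)(C)C)C1=O)C(=O)O` carries the same amino acid arm on a much smaller core; the difference between the two cores is not broken down here. In this assay compound 2 gives only a limit, > 200000 nM, meaning the assay reported no number for it. Compound 2 thus stands at the limit of > 200000 nM in this assay, at which 1 of the 3 values shown sits.

Compound 4 `C[C@H](NC1=CC(=O)C=C(C(C)(C)C)C1=O)C(=O)O` is to compound 2 what compound 3 is to compound 1: hydrogen in place of isopropyl on a saturated chain carbon, two bonds along the chain from an amine nitrogen and a carbonyl carbon. The place is the same in both pairs, so this is the same change made on the smaller core. On the larger core that change gave a 2.1-fold higher number from compound 1 to compound 3 (0.33 log units; beyond the scatter), a move toward a higher number. Since compound 2 already gives only a limit, compound 4 is expected to give only a limit as well, with an estimated step that the limit leaves unreadable from compound 2 to compound 4. The estimate for compound 4 in this assay is 350000 nM, expected to lie between 150000 nM and 900000 nM.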

Compound 4, half-maximal inhibitory concentration: > 200000 nM
Compound 4: no number, only a limit; the forecaster's own chance of this, stated with the estimate: 85%; the middle value does not contradict the limit.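

In this assay compound 4 gives only a limit, > 200000 nM. Compound 2 also gives only a limit, so no step can be read between compound 2 and compound 4, and both stand at the same limit: the limit of > 200000 nM in this assay, at which 2 of the 4 values shown sit. The compounds shown leave open how far hydrogen in place of isopropyl moves the number on the smaller core, and whether that step matches the one on the larger core.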